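The source may report more compounds than this note shows. Statements on the series, on what has been measured and on what is new or still open speak of the compounds shown alone.

Of the compounds shown here, three have been tested in an assay on isolated protein for inhibition of coagulation factor X (Oryctolagus cuniculus), tested at 1 uM; on this read-out higher numbers stand for more inhibition at the one concentration tested (going by the name of the read-out) and lower numbers for less inhibition. Compound 1 `O=C1[C@@H](NS(=O)(=O)c2cc3ccc(Cl)nc3s2)CCN1Cc1cc2cc[nH]cc-2n1` gives 50%, compound 2 `O=C1[C@@H](NS(=O)(=O)c2cc3c(Cl)nccc3s2)CCN1CCNc1ccncc1` gives 39%, and compound 3 `O=C1[C@@H](NS(=O)(=O)c2cc3c(Cl)nccc3s2)CCN1Cc1cc2c[nH]ccc-2n1` gives 35%, the lowest of the three numbers, though its gap to compound 2 lies within the scatter while compound 1 stands beyond the scatter above it. Compound 4 `CC(C)(C)c1ccc(S(=O)(=O)N[C@H]2CCN(Cc3cc4c[nH]ccc-4n3)C2=O)cc1` differs from compound 3 in one place: a group of 10 heavy atoms (10 carbon; one six-membered aromatic ring of carbon only) in place of a group of 10 heavy atoms (7 carbon, 1 nitrogen, 1 sulfur, 1 chlorine; one five-membered aromatic ring with 1 hetero atom, one six-membered aromatic ring with 1 hetero atom), on a sulfonyl sulfur. Among the measured compounds shown here, the only measured step, a number 4 percentage points lower from compound 2 to compound 3 (within the scatter), changed the group on the ring nitrogen, not the group on the sulfonyl sulfur, so it gives no guide to size or direction here. For the measured compounds named here, no measured compound carries a carbon-only ring at the sulfonyl sulfur, so the expectation is uncertain and leans toward weaker inhibition. Compound 4 is expected to give 20%, between 0% and 45%, an expected step of a number 15 percentage points lower from compound 3 to compound 4 (beyond the scatter).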

Compound 4, a percentage reported as inhibition, at one concentration (the size of the read-out at that concentration, not a potency): 14%
Estimate against measurement, compound 4: 6 percentage points above; measured number inside the range.
By their numbers in this assay, from the lowest: compound 4; then compounds 3 and 2 (each within the scatter of the next); then compound 1.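

Among the compounds shown here, with the rest of the molecule unchanged, the group on the sulfonyl sulfur clearly affects the result in this assay: placing 4-(tert-butyl)phenyl there in place of the chlorine-bearing two-ring group gives a number 21 percentage points lower from compound 3 to compound 4 (beyond the scatter) as the first measured step at this position. No available measurement explains this step. The compounds shown leave open which part of the departing group matters, since its ring count, chlorine, nitrogen and sulfur all change together. Naphthyl or 4-chlorophenyl on the sulfonyl sulfur, with the same remaining structure, would help separate these features.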